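A few compounds are considered here, and "the series" means these few. Any claim that something is new, unique, unknown or untested is made for them only; others in the source may bear on it.

Measured compounds:
compound 1 `CC1=CC[C@H](C(C)C)c2cc(C)c(OC(=O)c3ccc([N+](=O)[O-])cc3)cc21` in a functional assay on SK-LU-1 cells (Homo sapiens) for antiproliferative activity, read by sulforhodamine B assay, with a stated time of 48 h, tested at 50 uM; on this read-out higher numbers stand for more inhibition at the one concentration tested (going by the name of the read-out) and lower numbers for less inhibition: 47.5%
compound 2 `CC1=CC[C@H](C(C)C)c2cc(C)c(OC(=O)c3ccc(Cl)cc3)cc21` in this assay: 17.4%

For the measured compounds named here, compound 2 stands lowest of the two numbers measured so far; its nearest neighbour is compound 1, and the step of a number 30.1 percentage points lower from compound 1 to compound 2 (beyond the scatter) is beyond the scatter. Compound 3 `CC1=CC[C@H](C(C)C)c2cc(C)c(OC(=O)c3cccc(Cl)c3)cc21` is not yet measured. It differs from compound 2 by 3-chlorophenyl in place of 4-chlorophenyl on a carbonyl carbon. Going by the values given here, the only measured step, a number 30.1 percentage points lower from compound 1 to compound 2 (beyond the scatter), concerns the exchange of nitro for chloro and is large, but it does not involve a shift of the same group to another place on the ring, so it bears on the new step only indirectly: it shows that changes on this aromatic ring can move the read-out by a large amount. Among the compounds with values here, no measured pair shows what a 3-chlorophenyl does in place of a 4-chlorophenyl, so no direction can be taken from the data. Compound 3 is therefore expected to stay close to compound 2, with a step of a number 2.6 percentage points higher from compound 2 to compound 3 (within the scatter) that need not exceed the scatter. Compound 3 is estimated at 20%, within a range from 5% to 40%.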

Compound 3, a percentage reported as inhibition, at one concentration (the size of the read-out at that concentration, not a potency): 30.6%
Compound 3: middle estimate off by 10.6 percentage points, on the low side; the range from low to high includes it.
By their numbers in this assay, from the lowest: compound 2; then compound 3; then compound 1.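

The change from 4-chlorophenyl to 3-chlorophenyl on the carbonyl carbon gives, in this assay, a number 13.2 percentage points higher from compound 2 to compound 3 (beyond the scatter), which shows that the place of the chlorine on this ring matters on its own, with the same atoms joined differently, whereas the earlier pair showed only the exchange of one group for another. The comparison with the nitro compound gives a number 16.9 percentage points lower from compound 1 to compound 3 (beyond the scatter), so moving the chlorine recovers part of the inhibition but leaves 3-chlorophenyl short of 4-nitrophenyl at this concentration, and the read-out depends on both which group the ring carries and where the chlorine sits. Nothing available here bears on the reason for either step.

The compounds shown leave open how an amine, a methoxy group or a carboxylic acid on this ring would compare with chloro and nitro, and whether an amide in place of the ester linkage would keep the inhibition. Going by these compounds, all of the numbers are percentages at one concentration on one cell line, so how the compounds would rank by potency also remains open.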